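Series notes: tetrazole to thiadiazole on the thioether

The source may report more compounds than this note shows. Statements on the series, on what has been measured and on what is new or still open speak of the compounds shown alone.

The series shares the core of compound 1 `Cn1nnnc1SCC(=O)N/N=c1/scc(-c2ccccc2)n1-c1ccccc1`, a hydrazone carrying a thioether-linked five-membered heteroaromatic ring. In a functional assay on C6 cells (Rattus norvegicus) for cytotoxicity, read by MTT assay, with a stated time of 24 h, tested at 200 ug/mL (on this read-out higher numbers stand for a weaker effect at the one concentration tested and lower numbers for a stronger effect), compound 1 gives 26.8%. Among the compounds with values here, the only other measured member, compound 2 `Cn1nnnc1SCC(=O)N/N=c1/scc(-c2ccc(C#N)cc2)n1-c1ccccc1`, gives 28.6% in this assay, and the step of a number 1.8 percentage points higher from compound 1 to compound 2 (within the scatter) is the sole comparison available; compound 1 therefore has no measured neighbour whose number stands apart from its own.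

Compound 3 `Cc1nnc(SCC(=O)N/N=c2/scc(-c3ccccc3)n2-c2ccccc2)s1` differs from compound 1 by 5-methyl-1,3,4-thiadiazol-2-yl in place of 1-methyl-1H-tetrazol-5-yl on a sulfur. Within the data shown here, no measured step touches this position: the one recorded step concerns the aryl substituent, a different place, and its size is within the scatter. Nothing in the series therefore supports a shift in this assay beyond the scatter in either direction.

Compound 3 is expected to give about 27%, range 15% to 40%, in this assay. The expected step of a number 0.2 percentage points higher from compound 1 to compound 3 (within the scatter) is estimated to stay within the scatter.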

Compound 3, a percentage reported as activity, at one concentration (the size of the read-out at that concentration, not a potency): 59.2%
Compound 3: the middle estimate sits 32.2 percentage points below what was measured; measured number outside the range, above it.
By their numbers in this assay, from the lowest: compounds 1 and 2 (each within the scatter of the next); then compound 3.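

In this assay the ring on the sulfur proves to be a sensitive place: the exchange of 1-methyl-1H-tetrazol-5-yl for 5-methyl-1,3,4-thiadiazol-2-yl gives a number 32.4 percentage points higher from compound 1 to compound 3 (beyond the scatter) and so a clearly weaker effect at the one concentration tested. Within the data shown here, the earlier step on the aryl group, a number 1.8 percentage points higher from compound 1 to compound 2 (within the scatter) and no more, gave no sign of this, and the exchange on the sulfur is the first change with a size beyond the scatter. No evidence at hand accounts for the size of this step.

A single exchange does not separate the ring from its methyl group, and an unsubstituted 1,3,4-thiadiazol-2-yl or a 5-amino-1,3,4-thiadiazol-2-yl on the same sulfur would bear on that. On these data alone, whether the same exchange has a similar size with the cyano group of compound 2 in place also stays open.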